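Bromo for methyl on a second indole-bearing core

This account rests on a few compounds, and the source may have more. Where it says the series, first, only, none or still open, it means among the compounds named here.

Compound 1 `COC(=O)[C@@]1(C)CCC=C2[C@@H]1CC[C@@H](C)[C@]2(C)Cc1c[nH]c2ccc(C)cc12` gives 17000 nM in a functional assay on A549 cells (Homo sapiens) for inhibition, read by sulforhodamine B assay, with a stated time of 48 h; on this read-out lower numbers stand for stronger inhibition of growth and higher numbers for weaker inhibition of growth. Compound 2 `COC(=O)[C@@]1(C)CCC=C2[C@@H]1CC[C@@H](C)[C@]2(C)Cc1c[nH]c2ccc(Br)cc12` carries bromo in place of methyl on an aromatic carbon and in this assay compound 2 gives 15000 nM, a change of a 1.1-fold lower number from compound 1 to compound 2 (0.05 log units; within the scatter). Compound 3 `COC(=O)[C@@]1(C)CC[C@@H]2C3=C1CC[C@@H](C)[C@]3(C)Cc1c2[nH]c2ccc(C)cc12` rests on a core whose difference from that of compound 1 is not broken down here; in this assay compound 3 gives 16000 nM, within the scatter of compound 1 and compound 2. Compound 4 `COC(=O)[C@@]1(C)CC[C@@H]2C3=C1CC[C@@H](C)[C@]3(C)Cc1c2[nH]c2ccc(Br)cc12` carries bromo in place of methyl on an aromatic carbon, the same kind of change as from compound 1 to compound 2, though here the six-membered aromatic ring is part of a fused or bridged system of five rings rather than of two rings. From compound 3 to compound 4 a step of about a 1.1-fold lower number from compound 3 to compound 4 (0.04 log units; within the scatter) is expected in this assay, because the earlier step of a 1.1-fold lower number from compound 1 to compound 2 (0.05 log units; within the scatter) stayed within the scatter. Compound 4 is estimated at 14500 nM, between 7000 nM and 30000 nM.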

Compound 4, concentration for 50% growth inhibition: 17000 nM
Estimate against measurement, compound 4: 1.2-fold (0.07 log units) below; measured number inside the range.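

Working from this assay, bromo in place of methyl on an aromatic carbon gives a 1.1-fold higher number from compound 3 to compound 4 (0.03 log units; within the scatter). Set beside the step on the core of compound 1, the two steps agree: the same change on two cores in this assay, a 1.1-fold lower number (0.05 log units; within the scatter) from compound 1 to compound 2 and a 1.1-fold higher number (0.03 log units; within the scatter) from compound 3 to compound 4, 1.2-fold (0.08 log units) apart, within the scatter of two such steps

So on these two cores, this swap has no readable effect on growth inhibition in this assay. Neither step leaves the scatter. Among the compounds shown here, the agreement shows only that the swap is silent on both cores, not that a measurable effect carries from one core to the other, and it says nothing about further cores.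

Still open, on these data alone, is whether a group such as an amine or a carboxylic acid on that aromatic carbon would give a step beyond the scatter. Also open, as far as these compounds go, is whether such a step would match on the two cores.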